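The source may hold more compounds than are shown below. What is called first, only, known or untested is meant among the compounds shown, and "the series" means these compounds.

Compound 1 `Cc1ccc(Nc2nccc(-c3ccnc4ccccc34)n2)cc1` carries a 4-methylphenyl group on a ring nitrogen that compound 2 `Nc1nccc(-c2ccnc3ccccc23)n1` leaves bare as a plain amino group. In a functional assay on MCF7 cells (Homo sapiens) for cytotoxicity, read by sulforhodamine B assay, with a stated time of 48 h (on this read-out higher numbers stand for weaker inhibition and lower numbers for stronger inhibition), compound 1 gives 600 nM. In this assay compound 2 gives 40300 nM. Going by the values given here, the single change that separates them, (4-methylphenyl in place of hydrogen on a nitrogen on an aromatic ring), produces a 67-fold lower number from compound 2 to compound 1 (1.83 log units; beyond the scatter).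

Compound 3 `Nc1nccc(-c2cnc3ccccc3c2)n1` is built from the same atoms as compound 2, joined into a different core; the difference between the two cores is not broken down here. In this assay compound 3 reaches only a limit, > 50000 nM, so no number is known for it. Among the compounds with values here, compound 3 is the one value that sits at the limit of > 50000 nM in this assay, at which 1 of the 3 values shown sits.

Compound 4 `Cc1ccc(Nc2nccc(-c3cnc4ccccc4c3)n2)cc1` has not yet been measured in this assay. It stands to compound 3 exactly as compound 1 stands to compound 2: the same change, (4-methylphenyl in place of hydrogen on a nitrogen on an aromatic ring), at the same place, a nitrogen on an aromatic ring whose other neighbour is an aromatic carbon.

The step from compound 3 to compound 4 is expected to be an at least 16-fold lower number from compound 3 to compound 4 (1.22 log units; beyond the scatter), an expectation that rests on the earlier step of a 67-fold lower number from compound 2 to compound 1 (1.83 log units; beyond the scatter). The starting point is less sure here because compound 3 sits at the limit of > 50000 nM in this assay, at which 1 of the 3 values shown sits, rather than at a number, so the expected value for compound 4 is spread wider. Compound 4 is expected to give about 3000 nM, most likely falling between 500 nM and 30000 nM.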

Compound 4, half-maximal inhibitory concentration: 50000 nM
Beside the measured number, compound 4's estimate is 17-fold (1.22 log units) below it, outside the stated range (above it).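

The change to 4-methylphenyl gives a number no higher from compound 3 to compound 4 (the limit leaves the size open). The size of this step cannot be read, because compound 3 stands only at a limit: the limit of > 50000 nM in this assay, at which 1 of the 4 values shown sits.

Set beside the earlier step, the same change therefore gives only a loose comparison: the same change on two cores in this assay, a 67-fold lower number (1.83 log units; beyond the scatter) from compound 2 to compound 1 and a number no higher (the limit leaves the size open) from compound 3 to compound 4; the limit leaves it open whether they differ

In this assay compound 4 gives 50000 nM, which is a real number for the 4-methylphenyl compound on this core, but it does not show whether the change does less here than on the core of compound 2, and it does not show that the change does nothing here.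

The compounds shown carry only hydrogen or 4-methylphenyl on this nitrogen, so they leave open how other groups there, such as a longer chain, an amine or a carboxylic acid, would read on either core. They also leave open the true size of the step on the core of compound 3, which would take a number in place of a limit for compound 3.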